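The source may hold more compounds than are shown below. What is called first, only, known or untested is meant among the compounds shown, and "the series" means these compounds.

For the measured compounds named here, in a functional assay on MDA-MB-231 cells (Homo sapiens) for cytotoxicity, read by MTT assay, with a stated time of 72 h (a lower number here means a stronger inhibitor, a higher number a weaker inhibitor), compound 1 (`CN(C)CCCCCn1c2c(c3ccccc31)C(=O)c1c[n+]([O-])c3ccccc3c1C2=O`) gives 240 nM as the lower of the two numbers measured so far. Compound 2 (`O=C1c2c[n+]([O-])c3ccccc3c2C(=O)c2c1c1ccccc1n2Cc1cn([C@H]2O[C@H](CO)[C@@H](O)[C@H]2O)nn1`), with a different substituent on the shared core, gives 1700 nM as the higher number, and the gap between the two lies beyond the usual scatter. Compound 3 (`O=C1c2c[n+]([O-])c3ccccc3c2C(=O)c2c1c1ccccc1n2CCCCn1ccnc1`) has yet to be measured. It differs from compound 1 in one place (1H-imidazol-1-yl in place of (dimethylamino)methyl on a saturated chain carbon, four bonds along the chain from an aromatic nitrogen): 1H-imidazol-1-yl in place of (dimethylamino)methyl on a saturated chain carbon, four bonds along the chain from an aromatic nitrogen. Going by the values given here, no measured pair of compounds isolates this change, so any expectation rests on thin evidence. Among the compounds with values here, the one reading with another substituent, compound 2 at 1700 nM in this assay, sits on the weaker side of compound 1, and that leans the expectation in the same direction. The expected step is a 2.5-fold higher number from compound 1 to compound 3 (0.40 log units; beyond the scatter) towards a weaker inhibitor, a modest move just beyond the scatter. For compound 3 the estimated value is 600 nM with an expected range from 180 nM to 1800 nM in this measurement.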

Compound 3, half-maximal inhibitory concentration: 210 nM
Estimate against measurement, compound 3: 2.9-fold (0.46 log units) above; the range from low to high includes it.
By their numbers in this assay, from the lowest: compounds 3 and 1 (each within the scatter of the next); then compound 2.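

Read this assay, the step from the (dimethylamino)methyl group to 1H-imidazol-1-yl, on a saturated chain carbon, four bonds along the chain from an aromatic nitrogen, is a 1.1-fold lower number from compound 1 to compound 3 (0.06 log units; within the scatter) and gives the first single-place comparison at this position, since the earlier compounds offered none. It shows that, on the shared core, the open-chain amine end of compound 1 and the five-membered aromatic ring of compound 3 read alike, so a number in this range does not depend on keeping the (dimethylamino)methyl group at this position. Nothing available here accounts for the two groups reading alike.

The compounds shown leave open whether this tolerance extends to other groups on the same chain, such as a morpholine, a piperidine or a carboxylic acid, and whether 1H-imidazol-1-yl would read the same on a shorter or longer chain. They also leave open whether compound 1 and compound 3 would still read alike outside this assay, in other cell lines.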